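Pyridyl ether variation on the cyanopyridone series

The compounds below may be only part of what the source reports. "The series", "measured", "known", "first", "only" and "open" are said of these compounds alone.

Compound 1 `CC(C)CCn1ccc(-c2ccc(Oc3cccnc3)cc2)c(C#N)c1=O` is read in a functional assay on CHO cells for positive allosteric modulation of metabotropic glutamate receptor 2 (Homo sapiens), read by scintillation counting and GTPgammaS binding, with a stated time of 30 min (on this read-out higher numbers stand for an effect only at larger amounts of compound and lower numbers for an effect already at smaller amounts), where compound 1 gives 479 nM. Compound 2 `CC(C)CCn1ccc(-c2ccc(Oc3ccncc3)cc2)c(C#N)c1=O` gives 550 nM in this assay, and compound 3 `Cc1cc(Oc2ccc(-c3ccn(CC4CCC4)c(=O)c3C#N)cc2)ccn1` gives 126 nM. Among the measured compounds shown here, the only single-place step among the measured compounds is the one from compound 1 to compound 2, a 1.1-fold higher number from compound 1 to compound 2 (0.06 log units; within the scatter). On the three numbers shown compound 2 has the highest; compound 1 sits within the scatter of it, while the number of compound 3 lies beyond the scatter on the lower side. For the measured compounds named here, compound 3 differs from compound 2 in more than one place, so no single step connects them.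

Compound 4 `Cc1ccc(Oc2ccc(-c3ccn(CCC(C)C)c(=O)c3C#N)cc2)c(C)n1` is not yet measured. It differs from compound 2 in that (2,6-dimethylpyridin-3-yl in place of pyridin-4-yl on an oxygen on an aromatic ring). The step from compound 1 to compound 2 bears on this change only in part, since it moves the ring nitrogen without adding anything, and it was within the scatter. Going by the values given here, no measured step isolates the two added methyl groups. The lower number of compound 3, which also carries a methyl on its pyridine ring, is the only hint of a lower number, and it is confounded. For compound 4 a step of a 1.6-fold lower number from compound 2 to compound 4 (0.20 log units; within the scatter) is therefore expected, and its value in this assay is estimated at 350 nM, with a range from 120 nM to 1000 nM.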

Compound 4, half-maximal effective concentration: 100 nM
Beside the measured number, compound 4's estimate is 3.5-fold (0.54 log units) above it, and the stated range ends above it.
By their numbers in this assay, from the lowest: compounds 4 and 3 (each within the scatter of the next); then compounds 1 and 2 (each within the scatter of the next).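

In this assay the group on an oxygen on an aromatic ring now shows a step beyond the scatter: a 4.8-fold lower number from compound 1 to compound 4 (0.68 log units; beyond the scatter) is the cleanest reading. In this step pyridin-3-yl stays and only the two methyl groups enter. The step measured against the other pyridine runs the same way, a 5.5-fold lower number from compound 2 to compound 4 (0.74 log units; beyond the scatter) and, unlike moving the ring nitrogen alone in a 1.1-fold higher number from compound 1 to compound 2 (0.06 log units; within the scatter) which stayed within the scatter, it shows that this place does respond to a change of the group on the oxygen. Nothing at hand accounts for the lower number of compound 4.

The compounds shown leave open whether both methyl groups of 2,6-dimethylpyridin-3-yl are needed or one alone carries the step, so a 2-methylpyridin-3-yl and a 6-methylpyridin-3-yl group would separate the two. Also open, on these data alone, is how far this place tolerates something other than methyl on the same pyridine, such as ethyl, methoxy or a dimethylamino group, and whether the step holds with the cyclobutylmethyl group of compound 3 on the shared core.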